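From Benzyl to Benzoyl on a Ring Nitrogen

The source may hold more compounds than are shown below. What is called first, only, known or untested is meant among the compounds shown, and "the series" means these compounds.

For the measured compounds named here, three compounds sharing one core have so far been entered for a physicochemical assay for solubility, with a stated time of 3 days, at pH 2 (a higher number here means a more soluble compound, a lower number a less soluble compound), with only one number to show for it. For compound 1 `NC(=O)c1ccc2[nH]c(-c3ccc(OC4CCNCC4)cc3)nc2c1` the entry reads "not determined" (no result reported) and no result was reported. The same holds for compound 2 `COc1ccc(CN2CCCC(COc3ccc(-c4nc5cc(C(N)=O)ccc5[nH]4)cc3)C2)cc1` with its entry of "not determined" (no result reported) in the record. Going by the values given here, only compound 3 `NC(=O)c1ccc2[nH]c(-c3ccc(OCCC4CCN(Cc5ccccc5)CC4)cc3)nc2c1` gave a number, which is 110000 nM and which stands alone, with no other measured compound to rank it against.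

Compound 4 `NC(=O)c1ccc2[nH]c(-c3ccc(OCCC4CCN(C(=O)c5ccccc5)CC4)cc3)nc2c1` departs from compound 3 in a single place. The change is benzoyl in place of benzyl on an amine nitrogen in a ring and amounts to benzoyl in place of benzyl on an amine nitrogen in a ring, with the rest of the structure untouched.

Among the compounds with values here, no measured pair of compounds shows what such a swap does to the read-out. Within the data shown here, the expectation therefore rests on the structural change and on the one value of compound 3 at 110000 nM as its starting point. The expected step is a 3.7-fold lower number from compound 3 to compound 4 (0.56 log units; beyond the scatter) towards a lower number, beyond the usual scatter but held with wide uncertainty. For compound 4 the estimated value in this assay is 30000 nM (expected range 8000 nM to 90000 nM).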

Compound 4, solubility: 3000 nM
The estimate for compound 4 lay 10-fold (1.00 log units) above the measured number, outside the stated range (below it).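

In this assay, for the compounds shown here, the swap of benzyl for benzoyl on the amine nitrogen in a ring gives the only step that can be read, a 37-fold lower number from compound 3 to compound 4 (1.56 log units; beyond the scatter) and beyond the usual scatter, so a substituent change at this place can move the read-out a long way. The two groups share a six-membered aromatic ring of carbon only and neither carries a net charge, and what benzoyl brings that benzyl lacks is a carbonyl, with its hydrogen-bond acceptor, set directly on the ring nitrogen. Nothing at hand gives a measured reason for the size of this fall.

Going by these compounds, compound 1 and compound 2 have no reported number, so no comparison with them can be read, and the effect of the length and attachment of the chain that joins the ring nitrogen's ring to the shared core stays open. Also open, on these data alone, is how other groups on this nitrogen would compare with benzyl and benzoyl, for instance an acetyl group, a methanesulfonyl group or a phenyl urea, and whether a carbonyl alone is enough to produce a step of this size.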